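The compounds below may be only part of what the source reports. "The series", "measured", "known", "first", "only" and "open" are said of these compounds alone.

Within the data shown here, in a functional assay on A549 cells (Homo sapiens) for antiproliferative activity, read by MTT assay, with a stated time of 48 h (a lower number here means a stronger inhibitor, a higher number a weaker inhibitor), compound 2 `COc1cc2oc(-c3ccccc3)cc(=O)c2c(O)c1OCCCN1CCCCC1` gives 17000 nM, the higher of the two numbers measured so far. Among the measured compounds shown here, compound 1 `O=c1cc(-c2ccccc2)oc2cc(OCc3ccccc3)c(OCCCN3CCCCC3)c(O)c12` gives 3100 nM, and the only measured step, a 5.5-fold higher number from compound 1 to compound 2 (0.74 log units; beyond the scatter), concerns a change at the other end of the molecule. Compound 3 `COc1cc2oc(-c3ccccc3)cc(=O)c2c(O)c1OCCCCN1CCN(C)CC1` differs from compound 2 by (4-methylpiperazin-1-yl)methyl in place of piperidin-1-yl on a saturated chain carbon, three bonds along the chain from an oxygen on an aromatic ring. For the measured compounds named here, no measured step touches this part of the structure, so there is nothing to suggest a shift beyond the scatter. Compound 3 is therefore expected to sit close to compound 2, with a step of a 1.1-fold lower number from compound 2 to compound 3 (0.05 log units; within the scatter) and an estimated value of 15000 nM, ranging from 5000 nM to 50000 nM.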

Compound 3, half-maximal inhibitory concentration: 32000 nM
For compound 3 the middle estimate is 2.1-fold (0.33 log units) below the measured one; low and high end bracket the measured number.
By their numbers in this assay, from the lowest: compound 1; then compounds 2 and 3 (each within the scatter of the next).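

In this assay, replacing 2-(piperidin-1-yl)ethyl with 3-(4-methylpiperazin-1-yl)propyl gives a 1.9-fold higher number from compound 2 to compound 3 (0.27 log units; within the scatter) and so leaves the reading indistinguishable from scatter. This position therefore accepts the longer chain and the second ring nitrogen together without a clear shift in this measure. No measured evidence here offers an explanation for this result. Going by these compounds, because the chain and ring change at once, their separate contributions stay unknown. A 3-(piperidin-1-yl)propyl or 2-(4-methylpiperazin-1-yl)ethyl group would separate them, while a morpholine ring remains an open alternative.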